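Methoxy to Fluoro: Working Notes on Compound 4

The compounds below may be only part of what the source reports. "The series", "measured", "known", "first", "only" and "open" are said of these compounds alone.

Measured so far:
compound 1 `COc1ccc(Nc2nc(NCCCO)c3ccccc3n2)cc1`: 17100 nM
compound 2 `CNc1nc(Nc2ccc(OC)cc2)nc2ccccc12`: 17500 nM
compound 3 `COc1ccc(Nc2nc(NC3CC3)c3ccccc3n2)cc1`: 13400 nM

All three were read in a functional assay on KBVIN cells (Homo sapiens) for antiproliferative activity, read by sulforhodamine B assay, with a stated time of 48 h; a higher number here means a weaker inhibitor of growth, a lower number a stronger inhibitor of growth. Compound 1 stands second highest of the three numbers. Among the compounds with values here, the steps of a 1.0-fold higher number from compound 1 to compound 2 (0.01 log units; within the scatter) and a 1.3-fold lower number from compound 1 to compound 3 (0.11 log units; within the scatter) are both within the scatter, as is a 1.3-fold lower number from compound 2 to compound 3 (0.12 log units; within the scatter); the series so far is flat.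

Compound 4 `OCCCNc1nc(Nc2ccc(F)cc2)nc2ccccc12` alters a different place: fluoro in place of methoxy on an aromatic carbon. The three measured steps all vary the group on the other nitrogen on an aromatic ring and leave the 4-methoxyphenyl untouched, so none bears directly on this change. No step beyond the scatter is therefore expected in this assay; the estimated step is a 1.1-fold lower number from compound 1 to compound 4 (0.03 log units; within the scatter). Compound 4 is expected to give 16000 nM, within 5000 nM to 45000 nM.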

Compound 4, concentration for 50% growth inhibition: 24200 nM
The estimate for compound 4 lay 1.5-fold (0.18 log units) below the measured number; low and high end bracket the measured number.
By their numbers in this assay, from the lowest: compounds 3, 1, 2 and 4 (each within the scatter of the next).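

In this assay, within the data shown here, fluoro in place of methoxy gives a 1.4-fold higher number from compound 1 to compound 4 (0.15 log units; within the scatter), the first reading at this aromatic carbon. The methoxy, with its hydrogen-bond acceptor, can thus be exchanged for the smaller fluoro without a step beyond the scatter, so this position reads as flat as the group on the other nitrogen. No supporting measurement bears on this result.

Still open, as far as these compounds go, is whether an amine, a carboxylic acid or a longer chain on this carbon would give a step beyond the scatter.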